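This account rests on a few compounds, and the source may have more. Where it says the series, first, only, none or still open, it means among the compounds named here.

Measured compounds in a functional assay on Vero cells (Chlorocebus sabaeus) for cytotoxicity; a higher number here means that more compound is tolerated, a lower number that less compound is tolerated:
Compound 1 `CC(C)COC(=O)OCC(CO)CCn1cnc2cnc(N)nc21` gives > 500000 nM, a limit of the assay.
Compound 2 `CC(C)OC(=O)OCC(CO)CCn1cnc2cnc(N)nc21` gives > 500000 nM, a limit of the assay.
Compound 3 `COC(=O)OCC(CO)CCn1cnc2cnc(N)nc21` gives > 500000 nM, a limit of the assay.

Compound 1 stands only at a limit in this assay, and the two other values are limits as well, all three sitting at the limit of > 500000 nM in this assay, at which 3 of the 3 values shown sit. Compound 4 `CCOC(=O)OCC(CO)CCn1cnc2cnc(N)nc21` differs from compound 1 by methyl in place of isopropyl on a saturated chain carbon bound to an oxygen next to a carbonyl group. Within the data shown here, the steps that bear on this change are a step that the two limits leave unreadable from compound 1 to compound 2, a step that the two limits leave unreadable from compound 1 to compound 3 and a step that the two limits leave unreadable from compound 2 to compound 3; none of them can be read, as both ends sit at the limit. Across the measured compounds no change in the carbonate group has moved the read-out in this assay. The expected step is therefore a number no higher from compound 1 to compound 4 (the limit leaves the size open), none beyond the scatter. Compound 4 is estimated at 500000 nM, with a range from 250000 nM to 1000000 nM, most likely reported again only as a limit.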

Compound 4, half-maximal cytotoxic concentration: > 500000 nM
Compound 4 ended at the assay's limit (the forecaster's own chance of this, stated with the estimate: 85%); the middle value lies on the limit itself.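

No new step can be read in this assay from compound 4 to compound 1, compound 2 or compound 3, since all four sit at the same limit: the limit of > 500000 nM in this assay, at which 4 of the 4 values shown sit.

The compounds shown leave open whether any change in the carbonate group moves this read-out at all.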